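A few compounds are considered here, and "the series" means these few. Any claim that something is new, unique, unknown or untested is made for them only; others in the source may bear on it.

Compound 3 `CCOC(=O)CCCCCOc1cccc(CN(C(=O)c2ccc(-c3cccc(OC(C)C)c3)cc2)C(C)C)c1` is the starting point for the next step in the series. In an ADME assay on HepG2 cells (Homo sapiens) for cytotoxicity, read by CellTiter-Glo and resazurin assay, with a stated time of 72 h (a higher number here means that more compound is needed for the effect, a lower number that less compound is needed), compound 3 gives > 26000 nM, which is a limit of the assay and not a number. Its two neighbours stand in the same place. Compound 1 `COc1cccc(-c2ccc(C(=O)N(Cc3cccc(OCCCCCC(=O)O)c3)C(C)C)cc2)c1` gives > 26000 nM in this assay, again a limit. Compound 2 `CCOC(=O)CCCCCOc1cccc(CN(C(=O)c2ccccc2)C(C)C)c1` gives > 26000 nM in this assay, also a limit. The step that the two limits leave unreadable from compound 2 to compound 3 is therefore unreadable, because the limit of > 26000 nM in this assay, at which 3 of the 3 values shown sit, holds every value shown in this set.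

Compound 4 `CCOC(=O)CCCCCOc1cccc(CN(C(=O)c2ccc(-c3cccc(OC)c3)cc2)C(C)C)c1` differs from compound 3 in one place: methyl in place of isopropyl on an oxygen on an aromatic ring. No measured step in this assay bears on this change directly, and the one step that is shown, a step that the two limits leave unreadable from compound 2 to compound 3, could not be read against the limits. With three compounds all sitting at the limit, and with a change that is small in what it adds and removes, no step beyond the scatter is expected in this assay in either direction.

Compound 4 is therefore expected to give 40000 nM in this assay, with a range from 15000 nM to 100000 nM. This estimate amounts to a step that the limit leaves unreadable from compound 3 to compound 4, which is expected to stay within the usual scatter.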

Compound 4, half-maximal effective concentration: > 21000 nM
Compound 4 gave a limit, no number; the forecaster's own chance of this, stated with the estimate: 80%; the middle value is on the limit's open side.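

Compound 4 gives > 21000 nM in this assay, which is a limit and not a number. Among the compounds shown here, all four values shown are limits, and no step to compound 4 from compound 1, compound 2 or compound 3 can be read. The compounds shown leave open at what concentration any of them would reach the half-maximal effect in this assay.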